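Ring methyl on compound 3: expected dose in the rat

The compounds below may be only part of what the source reports. "The series", "measured", "known", "first", "only" and "open" are said of these compounds alone.

Measured in a functional assay on the whole organism with Rattus norvegicus as the target; on this read-out lower numbers stand for an effect already at smaller amounts and higher numbers for an effect only at larger amounts of compound:
- compound 1 `Nc1ccc(-c2ccc(O)nn2)cc1`: 20 umol/kg
- compound 2 `CC(=O)Nc1ccc(C2=NNC(=O)CC2)cc1`: 4 umol/kg
- compound 3 `Cc1ccccc1OCC(O)CNCC(=O)Nc1ccc(C2=NNC(=O)CC2)cc1`: 2 umol/kg

In this assay, compound 3 gives 2 umol/kg. This lies within the scatter of compound 2 at 4 umol/kg. Compound 1, at 20 umol/kg, has a higher number than compound 3, and that gap lies beyond the scatter.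

The next compound is compound 4 `Cc1ccccc1OCC(O)CNCC(=O)Nc1ccc(C2=NNC(=O)CC2C)cc1`, which carries methyl in place of hydrogen on a saturated ring carbon. Going by the values given here, no measured pair shows this change, so the size of the step cannot be read from the data and remains a judgement. A modest move toward a lower number is expected, and a result within the scatter of compound 3 would not be surprising. The expected step is a 2.5-fold lower number from compound 3 to compound 4 (0.40 log units; beyond the scatter). For compound 4 the estimated value is 0.8 umol/kg, with an expected range from 0.25 umol/kg to 2.5 umol/kg.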

Compound 4, dose for half-maximal effect: 2.7 umol/kg
The estimate for compound 4 lay 3.4-fold (0.53 log units) below the measured number; measured number above the stated range.
By their numbers in this assay, from the lowest: compounds 3, 4 and 2 (each within the scatter of the next); then compound 1.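

In this assay, methyl in place of hydrogen on a saturated ring carbon, next to the ring atom that bears a large group, gives a 1.4-fold higher number from compound 3 to compound 4 (0.13 log units; within the scatter), so this added carbon leaves the dose at this position indistinguishable from that with hydrogen. Going by these compounds alone, this is the first pair that differs in one place, and thus the first direct reading of a single change; the earlier compounds could not isolate any one position. Nothing measured here offers an explanation for this outcome.

From the compounds shown here alone, whether a longer chain such as ethyl, or a hydroxymethyl or an amine, on this same ring carbon would also stay within the scatter remains open. Also open, going by these compounds, is whether methyl at this place gives a similar step on the smaller compound 2.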